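Adding a Second Fluorine to the Benzyl Group of Compound 3

The compounds below may be only part of what the source reports. "The series", "measured", "known", "first", "only" and "open" are said of these compounds alone.

Compound 1, `COc1cccc(CN2Cc3c(NC(=O)c4ccccc4)n[nH]c3C2(C)C)c1`, in an assay on Sf21 cells for inhibition of high affinity nerve growth factor receptor (Homo sapiens), read by HTRF, with a stated time of 30 min, in the presence of a further agent that is not named here (on this read-out lower numbers stand for stronger inhibition and higher numbers for weaker inhibition), gives 1120 nM.
Compound 2, `CC1(C)c2[nH]nc(NC(=O)c3ccccc3)c2CN1Cc1cccc(Cl)c1`, in this assay gives 670 nM.
Compound 3, `CC1(C)c2[nH]nc(NC(=O)c3ccccc3)c2CN1Cc1ccccc1F`, in this assay gives 450 nM.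

Compound 3 has the lowest of the three numbers: the step of a 2.5-fold lower number from compound 1 to compound 3 (0.40 log units; beyond the scatter) lies beyond the scatter, while a 1.7-fold lower number from compound 1 to compound 2 (0.22 log units; within the scatter) and a 1.5-fold lower number from compound 2 to compound 3 (0.17 log units; within the scatter) stay within it. Compound 4, `CC1(C)c2[nH]nc(NC(=O)c3ccccc3)c2CN1Cc1cc(F)ccc1F`, differs from compound 3 by fluoro in place of hydrogen on an aromatic carbon. For the measured compounds named here, no measured step adds a substituent to a benzyl group that already carries one; all three exchange one substituted benzyl group for another, and each was small. No step beyond the scatter is therefore expected in this assay. Compound 4 is estimated at 400 nM, with a range from 180 nM to 900 nM, an expected step of a 1.1-fold lower number from compound 3 to compound 4 (0.05 log units; within the scatter).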

Compound 4, half-maximal inhibitory concentration: 480 nM
The estimate for compound 4 lay 1.2-fold (0.08 log units) below the measured number; measured number inside the range.
By their numbers in this assay, from the lowest: compounds 3, 4, 2 and 1 (each within the scatter of the next, the first and the last beyond it).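

In this assay, adding a fluoro group to the 2-fluorobenzyl group, para to the fluoro group already there, brings no change beyond the scatter: a 1.1-fold higher number from compound 3 to compound 4 (0.03 log units; within the scatter). The 2,5-difluorobenzyl compound also stays within the scatter of the 3-chlorobenzyl one, a 1.4-fold lower number from compound 2 to compound 4 (0.14 log units; within the scatter), but shows a 2.3-fold lower number from compound 1 to compound 4 (0.37 log units; beyond the scatter), a step beyond the scatter, as compound 3 did. Nothing available explains these results. The compounds shown leave open whether a larger group at this position, such as trifluoromethyl, or an amine or a carboxylic acid, would shift the number. They also leave open whether fluoro on another ring carbon would do so.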